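Two weak readings and a thiophene exchange

The compounds below may be only part of what the source reports. "The series", "measured", "known", "first", "only" and "open" are said of these compounds alone.

compound 1 `Cc1ccc(-c2nc3ccccn3c2Sc2ccccc2)cc1`: 83300 nM
compound 2 `c1ccc(Sc2c(-c3cccc4ccccc34)nc3ccccn23)cc1`: 60600 nM

In a functional assay on DU-145 cells (Homo sapiens) for inhibition, read by MTT assay, with a stated time of 48 h (a higher number here means a weaker inhibitor, a lower number a stronger inhibitor), compound 1 gives 83300 nM, and compound 2 gives 60600 nM, so the two numbers lie within the usual scatter of each other. Compound 3 `c1ccc(Sc2c(-c3ccsc3)nc3ccccn23)cc1` carries thiophen-3-yl in place of 4-methylphenyl on an aromatic carbon. For the measured compounds named here, no measured pair shows this exchange. The expected step of a 1.2-fold lower number from compound 1 to compound 3 (0.08 log units; within the scatter) in this assay therefore stays within the scatter, with no firm direction. For compound 3 the estimated value is 70000 nM, with an expected range of 30000 nM to 150000 nM.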

Compound 3, half-maximal inhibitory concentration: 85900 nM
Compound 3: the middle estimate sits 1.2-fold (0.09 log units) below what was measured, within the range that was stated.
By their numbers in this assay, from the lowest: compounds 2, 1 and 3 (each within the scatter of the next).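

In this assay, for the compounds shown here, the exchange of 4-methylphenyl for thiophen-3-yl on this aromatic carbon gives a 1.0-fold higher number from compound 1 to compound 3 (0.01 log units; within the scatter) and so provides the first step that can be read at this position. Within the scatter, a five-membered aromatic ring with 1 hetero atom and a six-membered aromatic ring of carbon only cannot be told apart here. The compounds shown leave open whether an amine or a carboxylic acid on this carbon would move the number beyond the scatter, and whether changing the phenylsulfanyl group would do so. No measurement at hand accounts for this result.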